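A few compounds are considered here, and "the series" means these few. Any claim that something is new, unique, unknown or untested is made for them only; others in the source may bear on it.

Of the compounds shown here, two have so far been tested in a functional assay on cells (Platelet, Homo sapiens) for inhibition; on this read-out lower numbers stand for stronger inhibition and higher numbers for weaker inhibition. Compound 1, `CCOC(=O)c1cccc(-c2n[nH]c3ccccc23)c1`, carries the shared core with a free ring nitrogen; in this assay compound 1 returns only a limit of the measurement, > 10000 nM. Compound 2, `CCOC(=O)c1ccc(-c2nn(Cc3ccccc3F)c3ccccc23)cc1`, carries a 2-fluorobenzyl group on that nitrogen; in this assay compound 2 likewise returns only a limit, > 10000 nM. Compound 2 therefore stands at the edge of what this assay can report, the same place at which every value recorded so far sits (the limit of > 10000 nM in this assay, at which 2 of the 2 values shown sit). Within the data shown here, no step between two measured compounds is available, so nothing is yet known about what any change at that position does here.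

Compound 3, `CCOC(=O)c1ccc(-c2nn(Cc3ccccn3)c3ccccc23)cc1`, differs from compound 2 by a single exchange: pyridin-2-yl in place of 2-fluorophenyl on a saturated chain carbon bound to an aromatic nitrogen. With compound 2 giving only a limit, no direction can be read from the numbers, and the step is expected to be a step that the limit leaves unreadable from compound 2 to compound 3, that is, none beyond the scatter. Compound 3 is accordingly expected to fall at 15000 nM, within 4000 nM to 60000 nM, and most likely to be reported again only as a limit.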

Compound 3, half-maximal inhibitory concentration: > 10000 nM
Compound 3: no number, only a limit (the forecaster's own chance of this, stated with the estimate: 80%); the middle value is on the limit's open side.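

In this assay compound 3 returns only a limit, > 10000 nM. Among these compounds, no step from compound 2 to compound 3 can therefore be read, so the exchange of 2-fluorophenyl for pyridin-2-yl has no readable size. The compounds shown leave open whether any compound of this series gives a measurable inhibition value, as all remain at one limit: the limit of > 10000 nM in this assay, at which 3 of the 3 values shown sit.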